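Small ring substituents on a shared flavanone-derived core

The source may report more compounds than this note shows. Statements on the series, on what has been measured and on what is new or still open speak of the compounds shown alone.

Compound 1 `COc1ccc([C@@H]2CC(=O)c3c(O)cc(OCc4cn(CC5CC5)nn4)cc3O2)cc1O` — 11900 nM
Compound 2 `COc1ccc([C@@H]2CC(=O)c3c(O)cc(OCc4cn(Cc5ccc(C(F)(F)F)cc5)nn4)cc3O2)cc1O` — 17700 nM
Compound 3 `C=CCn1cc(COc2cc(O)c3c(c2)O[C@H](c2ccc(OC)c(O)c2)CC3=O)nn1` — 13800 nM

All three compounds were tested in a functional assay on RAW264.7 cells (Mus musculus) for inhibition, read by Griess assay, with stated times of 2 h and 24 h; on this read-out higher numbers stand for weaker inhibition and lower numbers for stronger inhibition. Compound 3 holds the second highest of the three numbers; its nearest neighbour is compound 1, and the gap between them is read in a 1.2-fold higher number from compound 1 to compound 3 (0.06 log units; within the scatter). Its furthest neighbour is compound 2, and that gap is read in a 1.3-fold lower number from compound 2 to compound 3 (0.11 log units; within the scatter). The remaining pair is covered by a 1.5-fold higher number from compound 1 to compound 2 (0.17 log units; within the scatter). None of these three steps leaves the scatter, so the three substituents on the saturated chain carbon bound to the aromatic nitrogen are, on this read-out, not distinguishable from each other.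

Compound 4 `COc1ccc([C@@H]2CC(=O)c3c(O)cc(OCc4cn(C5CCC5)nn4)cc3O2)cc1O` has not yet been measured. It differs from compound 3 as follows: cyclobutyl in place of allyl on an aromatic nitrogen. The step from compound 1 to compound 3, which swaps cyclopropyl for vinyl on a saturated chain carbon bound to an aromatic nitrogen, is the nearest comparison and stayed within the scatter, as did the other two. Compound 4 is therefore expected to show no shift beyond the scatter, a 1.1-fold lower number from compound 3 to compound 4 (0.03 log units; within the scatter). Compound 4 is estimated at 13000 nM in this assay, with a range from 6500 nM to 26000 nM.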

Compound 4, half-maximal inhibitory concentration: 15300 nM
Compound 4: the middle estimate sits 1.2-fold (0.07 log units) below what was measured, and the stated range covers the measured number.
By their numbers in this assay, from the lowest: compounds 1, 3, 4 and 2 (each within the scatter of the next).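

Compound 4 is the only one of the four that carries a ring directly on the aromatic nitrogen, and in this assay this placement stays level with the earlier groups: replacing allyl with cyclobutyl gives a 1.1-fold higher number from compound 3 to compound 4 (0.04 log units; within the scatter), even though the change removes a double bond outside aromatic rings and adds a four-membered ring of carbon only. The comparisons with the two groups that hold their ring one chain carbon away from the nitrogen read the same way, with a 1.3-fold higher number from compound 1 to compound 4 (0.11 log units; within the scatter) for cyclopropylmethyl and a 1.2-fold lower number from compound 2 to compound 4 (0.06 log units; within the scatter) for 4-(trifluoromethyl)benzyl, so at this position the four groups shown cannot be told apart on this read-out. Nothing shown here offers an explanation for this flat result.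

The compounds shown leave open whether any group on this nitrogen can move the number beyond the scatter, for instance an amine, a carboxylic acid or a longer chain. They also leave open whether the shared core, which is the same in all four compounds, matters more to this read-out than the group on the aromatic nitrogen does.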